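The source may report more compounds than this note shows. Statements on the series, on what has been measured and on what is new or still open speak of the compounds shown alone.

Working notes on the series in a functional assay on CCRF-CEM cells (Homo sapiens) for inhibition, read by cell counting, with a stated time of 3 days; on this read-out lower numbers stand for stronger inhibition and higher numbers for weaker inhibition. Compound 2 `C=C(Br)C(=O)Nc1cccc(-c2cn3nc(Cc4ccc(Cl)cc4)sc3n2)c1` gives 3300 nM in this assay. Its nearest neighbour is compound 1 `C=C(Br)C(=O)Nc1cccc(-c2cn3nc(Cc4cccc(OC)c4)sc3n2)c1`, which in this assay gives 3100 nM; the step of a 1.1-fold higher number from compound 1 to compound 2 (0.03 log units; within the scatter) lies within the scatter, so the two numbers are treated as indistinguishable. Compound 3 `C=C(Br)C(=O)Nc1cccc(-c2cn3nc(-c4ccc(C)cc4)sc3n2)c1` is not yet measured. It differs from compound 2 in one place: 4-methylphenyl in place of 4-chlorobenzyl on an aromatic carbon. Going by the values given here, the only measured step exchanges the aryl ring on the saturated chain carbon and is within the scatter; no measured pair removes that chain carbon or attaches an aryl ring directly to the aromatic carbon of the five-membered ring. On this basis no step beyond the scatter is expected, but the change is of a kind the series has not yet tested, so the range is kept wide. The expected step is a 1.1-fold lower number from compound 2 to compound 3 (0.04 log units; within the scatter). Compound 3 is estimated at 3000 nM, with a range from 900 nM to 10000 nM.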

Compound 3, half-maximal inhibitory concentration: 1700 nM
Estimate against measurement, compound 3: 1.8-fold (0.25 log units) above; the range from low to high includes it.
By their numbers in this assay, from the lowest: compounds 3, 1 and 2 (each within the scatter of the next).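

In this assay, removing the saturated chain carbon and placing the aryl ring directly on the aromatic carbon of the five-membered ring gives no step beyond the scatter. The step of a 1.9-fold lower number from compound 2 to compound 3 (0.29 log units; within the scatter) and the step of a 1.8-fold lower number from compound 1 to compound 3 (0.26 log units; within the scatter) both stay within it, so 4-methylphenyl at this position cannot be told apart from either 4-chlorobenzyl or 3-methoxybenzyl. The series thus extends from exchanges of the ring on the chain carbon to a change in the link itself, and no supporting measurement bears on this result.

Compound 3 changes the link and the ring substituent together, so the contribution of each remains unseparated. Also open, on these data alone, is how this position responds to a group without an aryl ring, such as an amine, or to a longer chain between the aryl ring and the shared core.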